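The source may report more compounds than this note shows. Statements on the series, on what has been measured and on what is new or still open speak of the compounds shown alone.

Three compounds have so far been measured in a functional assay on NCI-H460 cells (Homo sapiens) for antiproliferative activity, read by MTT assay, with a stated time of 48 h; a higher number here means a weaker inhibitor, a lower number a stronger inhibitor:

Compound 1, `CC(C)CCC1(O)C(=O)Nc2ccc(Nc3ccc(Cl)cc3)cc21`: 25000 nM
Compound 2, `CCCCCCC1(O)C(=O)Nc2ccc(Nc3ccc(Cl)cc3)cc21`: 30300 nM
Compound 3, `CC(C)CCC1(O)C(=O)Nc2ccc(Nc3ccc(C(F)(F)F)cc3)cc21`: 17200 nM

Compounds 1 and 2 share the same core and differ only in the chain on the saturated ring carbon: butyl in place of isopropyl on a saturated chain carbon, two bonds along the chain from a saturated ring carbon. In this assay this change gave a 1.2-fold higher number from compound 1 to compound 2 (0.08 log units; within the scatter). Compounds 1 and 3 carry the same chain and differ on the aromatic ring: trifluoromethyl in place of chloro on an aromatic carbon. That change gave a 1.5-fold lower number from compound 1 to compound 3 (0.16 log units; within the scatter). All three values lie within the usual scatter of one another, so none of the three compounds can be set apart from the others on these numbers.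

Compound 4, `CCCCCCC1(O)C(=O)Nc2ccc(Nc3ccc(C(F)(F)F)cc3)cc21`, has not yet been measured. It differs from compound 3 by butyl in place of isopropyl on a saturated chain carbon, two bonds along the chain from a saturated ring carbon, which is the same change that leads from compound 1 to compound 2, and the place of the change is described in the same words in both cases. Going by the values given here, the only guide to the size of the coming step is the earlier one, a 1.2-fold higher number from compound 1 to compound 2 (0.08 log units; within the scatter), which lay within the scatter. Compound 4 is therefore expected to move by a similarly small amount, a 1.2-fold higher number from compound 3 to compound 4 (0.09 log units; within the scatter). This expectation rests on the value of compound 3, 17200 nM, and on the earlier step of a 1.2-fold higher number from compound 1 to compound 2 (0.08 log units; within the scatter). The estimate for compound 4 is 21000 nM, with a likely range from 10000 nM to 45000 nM.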

Compound 4, half-maximal inhibitory concentration: 18800 nM
For compound 4 the middle estimate is 1.1-fold (0.05 log units) above the measured one; the measured number falls inside the stated range.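

Carrying butyl in place of isopropyl from the core of compound 1 to the core of compound 3 gave steps that cannot be told apart in this assay: the same change on two cores in this assay, a 1.2-fold higher number (0.08 log units; within the scatter) from compound 1 to compound 2 and a 1.1-fold higher number (0.04 log units; within the scatter) from compound 3 to compound 4, 1.1-fold (0.04 log units) apart, within the scatter of two such steps. Trifluoromethyl in place of chloro behaved the same way when the chain was changed: the same change on two cores in this assay, a 1.5-fold lower number (0.16 log units; within the scatter) from compound 1 to compound 3 and a 1.6-fold lower number (0.21 log units; within the scatter) from compound 2 to compound 4, 1.1-fold (0.04 log units) apart, within the scatter of two such steps. With the new steps, a 1.1-fold higher number from compound 3 to compound 4 (0.04 log units; within the scatter) and a 1.6-fold lower number from compound 2 to compound 4 (0.21 log units; within the scatter), all the steps among these compounds lie within the scatter, so the agreement shows only that neither change separates the compounds on either core, not that either change has a real effect of a fixed size that carries from one core to another.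

The compounds shown leave open whether a step beyond the scatter could be seen at all in this series, for instance with a longer chain or a chain ending in an amine at the saturated ring carbon, or with a nitrile or a carboxylic acid in place of trifluoromethyl on the aromatic carbon. They also leave open whether the two changes would again give matching steps on a core where the values in this assay lie further apart.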